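Methyl for chloro on the dichlorophenyl amide

The source may hold more compounds than are shown below. What is called first, only, known or untested is meant among the compounds shown, and "the series" means these compounds.

Among the measured compounds shown here, compound 1 `O=C(Nc1ccc(Cl)c(C(=O)Nc2ccc(-c3ncc[nH]3)nc2)c1)c1ccc(Cl)c(Cl)c1` is the only member of the series with a number: in a functional assay on MDA-MB-453 cells (Homo sapiens) for cytotoxicity, read by MTT assay, with a stated time of 72 h (on this read-out lower numbers stand for stronger inhibition and higher numbers for weaker inhibition), compound 1 gives 11400 nM, so it stands alone on this read-out and cannot be ranked against anything. Compound 2 `O=C(Nc1ccc(Cl)c(Cl)c1)c1ccc(Cl)c(C(=O)Nc2ccc(-c3ncc[nH]3)nc2)c1`, the reversed-amide isomer, has no result in this assay: for compound 2 the entry reads "not determined" (no result reported).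

Compound 3 `Cc1cc(C(=O)Nc2ccc(Cl)c(C(=O)Nc3ccc(-c4ncc[nH]4)nc3)c2)ccc1Cl` differs from compound 1 in one place: methyl in place of chloro on an aromatic carbon, turning the 3,4-dichlorophenyl group into a 4-chloro-3-methylphenyl group. For the measured compounds named here, with no measured step to lean on, a small step is expected, in no firm direction, and most likely not beyond the usual scatter of this assay.

Compound 3 is expected at 14000 nM, within a range of 5000 nM to 40000 nM. The expected step from compound 1 to compound 3 in this assay is estimated at a 1.2-fold higher number from compound 1 to compound 3 (0.09 log units; within the scatter).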

Compound 3, half-maximal inhibitory concentration: 8760 nM
Compound 3: middle estimate off by 1.6-fold (0.20 log units), on the high side; measured number inside the range.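

In this assay, among the compounds shown here, the change from 3,4-dichlorophenyl to 4-chloro-3-methylphenyl gives a 1.3-fold lower number from compound 1 to compound 3 (0.11 log units; within the scatter) and provides the first reading at this position. For this one pair, methyl in place of chloro leaves the read-out within the scatter, so this chloro group is not needed to hold the number at the level of compound 1. Nothing measured on these compounds accounts for the size of this step.

From the compounds shown here alone, whether an amine, a carboxylic acid or a longer chain such as propyl at this position would move the number beyond the scatter remains open. Steps involving compound 2 cannot be read, so the effect of reversing the amide also remains open.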